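The compounds below may be only part of what the source reports. "The series", "measured", "known", "first", "only" and "open" are said of these compounds alone.

Measured compounds in an assay on brain (strain Sprague-Dawley) for displacement of a labelled ligand from sodium-dependent dopamine transporter (Rattus norvegicus), read by scintillation counting, with a stated time of 120 min; on this read-out lower numbers stand for stronger inhibition and higher numbers for weaker inhibition:
compound 1, `CNC(=O)CSC(c1ccccc1)c1ccccc1`, 19300 nM
compound 2, `[O-][S+](CCNCCCc1ccccc1)C(c1ccc(Br)cc1)c1ccc(Br)cc1`, 1270 nM
compound 3, `O=C(CSC(c1ccc(Br)cc1)c1ccc(Br)cc1)NCCCc1ccccc1`, 238 nM

Compound 1 gives the highest number of the three, so it is the weakest binder here. Its nearest neighbour is compound 2, whose value stands well beyond the scatter from compound 1; compound 3 lies further still, also beyond the scatter. Compound 3 differs from compound 1 in more than one place, so its lower number cannot be assigned to any single change.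

The unmeasured compound 4, `CCCNC(=O)CSC(c1ccccc1)c1ccccc1`, differs from compound 1 by ethyl in place of hydrogen on a saturated chain carbon bound to an amide-type nitrogen. Among the measured compounds shown here, no measured pair in the set isolates this change, so nothing in the data fixes its size. With only the methyl-to-propyl lengthening at the amide nitrogen, a modest step towards a lower number in this assay is expected, though it may not exceed the scatter. For compound 4 the estimate is 7500 nM, range 2500 nM to 22000 nM. The expected step is a 2.6-fold lower number from compound 1 to compound 4 (0.41 log units; beyond the scatter).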

Compound 4, inhibition constant: 20700 nM
Estimate against measurement, compound 4: 2.8-fold (0.44 log units) below; low and high end bracket the measured number.
By their numbers in this assay, from the lowest: compound 3; then compound 2; then compounds 1 and 4 (each within the scatter of the next).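

Methylcarbamoyl to propylcarbamoyl is the first single change that can be read in this assay, and it gives a 1.1-fold higher number from compound 1 to compound 4 (0.03 log units; within the scatter). Among the compounds shown here, on the core of compound 1, this position therefore takes ethyl in place of hydrogen on a saturated chain carbon bound to an amide-type nitrogen with no readable difference in either direction, which the earlier compounds, all differing in more than one place, could not show. No measured data bear on why the number holds at this position.

Going by these compounds, whether a butyl or hexyl chain in place of propyl, or an amine or a carboxylic acid on that chain, would move the number remains open. On these data alone, it also remains open whether the same methyl to propyl change reads alike on the core of compound 3.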